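The source may hold more compounds than are shown below. What is called first, only, known or untested is meant among the compounds shown, and "the series" means these compounds.

Compound 1 `COc1cc2ncnc(Nc3ccc(OCc4cccc(F)c4)c(Cl)c3)c2cc1OCCCCC(=O)Nc1ccc(S(N)(=O)=O)cc1` gives 7860 nM in a functional assay on A549 cells (Homo sapiens) for antiproliferative activity, read by MTT assay, with a stated time of 72 h; a lower number here means a stronger inhibitor, a higher number a weaker inhibitor. Within the data shown here, compound 2 `C#Cc1cccc(Nc2ncnc3ccc(NC(=S)Nc4ccc(S(N)(=O)=O)cc4)cc23)c1` returns only a limit in this assay, > 40000 nM; this is the limit of > 40000 nM in this assay, at which 1 of the 2 values shown sits, so compound 2 stands at the limit and no step between compound 1 and compound 2 is counted. Compound 3 `NS(=O)(=O)c1ccc(NC(=S)Nc2ccc3ncnc(Nc4ccc(Cl)c(C(F)(F)F)c4)c3c2)cc1` differs from compound 2 by 4-chloro-3-(trifluoromethyl)phenyl in place of 3-ethynylphenyl on a nitrogen on an aromatic ring. Among the measured compounds shown here, with compound 2 at the limit, no measured step fixes the size or direction of this change; the expected step is an at least 1.3-fold lower number from compound 2 to compound 3 (0.12 log units; that floor lies within the scatter). Compound 3 is estimated at 30000 nM in this assay, range 8000 nM to 100000 nM, and a limit remains likely.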

Compound 3, half-maximal inhibitory concentration: 4500 nM
Compound 3: middle estimate off by 6.7-fold (0.82 log units), on the high side; measured number outside the range, below it.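

The aryl group on a nitrogen on an aromatic ring can move the number in this assay: 4-chloro-3-(trifluoromethyl)phenyl in place of 3-ethynylphenyl gives an at least 8.8-fold lower number from compound 2 to compound 3 (0.94 log units; beyond the scatter). Compound 2 stands at a limit, so this step is a floor and not a size: the limit of > 40000 nM in this assay, at which 1 of the 3 values shown sits.

The compounds shown do not separate the chlorine from the trifluoromethyl, so a phenyl carrying only one of the two remains an open comparison. On these data alone, how far the number would move with a nitrile on this phenyl also remains open.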